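Swapping the aryl group on a shared anilide core

This account rests on a few compounds, and the source may have more. Where it says the series, first, only, none or still open, it means among the compounds named here.

Compound 1, `C=CC(=O)Nc1cccc(NC(=O)CSc2nc(Nc3cccc([N+](=O)[O-])c3)c3ccccc3n2)c1`, in a functional assay on MDA-MB-231 cells (Homo sapiens) for inhibition, read by MTT assay, with a stated time of 72 h (on this read-out higher numbers stand for weaker inhibition and lower numbers for stronger inhibition), gives only a limit of > 50000 nM.
Compound 2, `C=CC(=O)Nc1cccc(NC(=O)CSc2nc(Nc3ccc(F)cc3)c3ccccc3n2)c1`, in this assay gives 9490 nM.

Compound 2 therefore holds the only number shown in this assay; the other value is a limit, (the limit of > 50000 nM in this assay, at which 1 of the 2 values shown sits). Compound 3, `C=CC(=O)Nc1cccc(NC(=O)CSc2nc(Nc3ccc(Cl)cc3Cl)c3ccccc3n2)c1`, differs from compound 2 by 2,4-dichlorophenyl in place of 4-fluorophenyl on a nitrogen on an aromatic ring. Among the compounds with values here, the single measured step, an at least 5.2-fold lower number from compound 1 to compound 2 (0.72 log units; beyond the scatter), changes the same place but exchanges a different group, so it does not say how two chlorines compare with one fluorine. Compound 3 is therefore expected to move by a 1.5-fold lower number from compound 2 to compound 3 (0.16 log units; within the scatter), a change likely within the scatter. Compound 3 is estimated at 6500 nM, between 1500 nM and 28000 nM.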

Compound 3, half-maximal inhibitory concentration: 23100 nM
Beside the measured number, compound 3's estimate is 3.6-fold (0.55 log units) below it, within the range that was stated.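

At this place, on a nitrogen on an aromatic ring, the two halogen-bearing aryl groups do not read alike: 2,4-dichlorophenyl in place of 4-fluorophenyl gives a 2.4-fold higher number from compound 2 to compound 3 (0.39 log units; beyond the scatter) in this assay. So the position separates these two groups as well, not only 3-nitrophenyl from 4-fluorophenyl. Against 3-nitrophenyl, the 2,4-dichlorophenyl group still shows an at least 2.1-fold lower number from compound 1 to compound 3 (0.33 log units; beyond the scatter), a step that rests on a limit: the limit of > 50000 nM in this assay, at which 1 of the 3 values shown sits.

The compounds shown leave open which of the two chlorines accounts for the step from 4-fluorophenyl. As far as these compounds go, how an unsubstituted phenyl group, or a phenyl group carrying a single chlorine or a methoxy group, would read at this place also remains open.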